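The source may report more compounds than this note shows. Statements on the series, on what has been measured and on what is new or still open speak of the compounds shown alone.

Compound 1 `CCCCCCCCc1ccc(OCC(=O)Cn2nnc(SC)n2)cc1`: < 5%
Compound 2 `CCCCCCCCc1ccc(OCC(=O)Cn2nnc(-c3cccc(C(=O)OC)c3)n2)cc1`: 19%

Of the compounds shown here, two have been measured in an ADME assay on S9 fraction from liver (Rattus norvegicus) for metabolic stability, read by LC-MS, using NADPH, with a stated time of 30 min; a higher number here means that more of the compound is left, a lower number that less of the compound is left. Compound 1 gives < 5%, and this is a limit of the assay rather than a number, so compound 1 stands at the very bottom of what this assay can report, as the limit of < 5% in this assay, at which 1 of the 2 values shown sits, makes plain. Compound 2 gives 19%, a real number. For the measured compounds named here, the single measured step, a number at least 14 percentage points higher from compound 1 to compound 2 (beyond the scatter), shows that exchanging the methylsulfanyl for an aromatic group lifted the reading out of the limit region.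

Compound 3 `CCCCCCCCc1ccc(OCC(=O)Cn2nnc(Cc3ccccc3)n2)cc1` differs from compound 1 in one place only: benzyl in place of methylsulfanyl on an aromatic carbon. Going by the values given here, the only measured step that bears on this change is a number at least 14 percentage points higher from compound 1 to compound 2 (beyond the scatter), in which the methylsulfanyl likewise gave way to a larger carbon-based group; because that step was a number at least 14 percentage points higher from compound 1 to compound 2 (beyond the scatter), an increase beyond the scatter is also expected for compound 3, though a benzyl is not the same as the group entering in compound 2, so the size is uncertain. The step expected is a number at least 10 percentage points higher from compound 1 to compound 3 (that floor lies within the scatter). Compound 3 is therefore estimated at 15%, with a likely range from 3% to 35%.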

Compound 3, percent of the compound remaining: < 5%
Compound 3: no number, only a limit; the forecaster's own chance of this, stated with the estimate: 25%; middle value at least 10 percentage points from the limit.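

In this assay compound 3 gives < 5%, which is a limit of the assay and not a number. Replacing the 3-(methoxycarbonyl)phenyl of compound 2 with benzyl gives a number at least 14 percentage points lower from compound 2 to compound 3 (beyond the scatter), so a larger carbon-based group at this place, even one with a six-membered aromatic ring, does not by itself keep the reading clear of the limit; what enters matters, not merely that methylsulfanyl leaves. The step between compound 1 and compound 3 cannot be read, since the two compounds sit at the same limit and no size can be given for the change from methylsulfanyl to benzyl: the limit of < 5% in this assay, at which 2 of the 3 values shown sit.

Compound 2 alone gives a real number, so the compounds shown cannot say whether its higher reading belongs to the methoxycarbonyl group or to the aromatic ring that carries it. Going by these compounds, it also stays open whether a plain phenyl at this place, or a carboxylic acid in place of the methoxycarbonyl, would read like compound 2 or like compound 3.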